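Swapping the Triazole Substituent for a Second Chloroquinoline

The source may report more compounds than this note shows. Statements on the series, on what has been measured and on what is new or still open speak of the compounds shown alone.

Of the compounds shown here, two sharing one core have been measured in a functional assay on HCC827 cells (Homo sapiens) for antiproliferative activity, read by sulforhodamine B assay, with a stated time of 72 h; on this read-out higher numbers stand for weaker inhibition and lower numbers for stronger inhibition. Compound 1 `CN(CCNCc1cn(Cc2ccc(Br)cc2)nn1)CCNc1ccnc2cc(Cl)ccc12` carries a 4-bromobenzyl group on a triazole nitrogen and gives 9300 nM. Compound 2 `CN(CCNCc1cn(-c2nc3ccccc3[nH]2)nn1)CCNc1ccnc2cc(Cl)ccc12` has a 1H-benzimidazol-2-yl group at the same place and gives 32000 nM, the higher of the two numbers; the step of a 3.4-fold higher number from compound 1 to compound 2 (0.54 log units; beyond the scatter) was beyond the scatter and therefore counts as a real, if modest, loss of antiproliferative strength.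

Compound 3 `CN(CCNCc1cn(-c2ccnc3cc(Cl)ccc23)nn1)CCNc1ccnc2cc(Cl)ccc12` is the next variation: 7-chloroquinolin-4-yl in place of 1H-benzimidazol-2-yl on an aromatic nitrogen. Going by the values given here, only one measured step bears on this change, the one from compound 1 to compound 2, and it shows that exchanging the group on this nitrogen moves the number by a modest amount rather than dramatically. The incoming group is an aromatic ring system attached directly to the nitrogen, as in compound 2, so a result in the same general region is expected, perhaps drifting back toward compound 1. The expected step of a 2.1-fold lower number from compound 2 to compound 3 (0.33 log units; beyond the scatter) is estimated to be small. For compound 3 the estimate is 15000 nM, with a range from 4000 nM to 50000 nM.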

Compound 3, half-maximal inhibitory concentration: 18000 nM
The estimate for compound 3 lay 1.2-fold (0.08 log units) below the measured number; low and high end bracket the measured number.
By their numbers in this assay, from the lowest: compounds 1, 3 and 2 (each within the scatter of the next, the first and the last beyond it).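

In this assay, putting 7-chloroquinolin-4-yl on the aromatic nitrogen gives a 1.8-fold lower number from compound 2 to compound 3 (0.25 log units; within the scatter), and set against the 4-bromobenzyl group the same position shows a 1.9-fold higher number from compound 1 to compound 3 (0.29 log units; within the scatter). Going by these compounds alone, compound 3 therefore cannot be told apart from either of the other two, even though its group has more heavy atoms than 1H-benzimidazol-2-yl, carries a chlorine and lacks that group's hydrogen-bond donor; the only step here that clearly exceeds the scatter remains a 3.4-fold higher number from compound 1 to compound 2 (0.54 log units; beyond the scatter). Nothing available explains why these exchanges change the number so little.

Going by these compounds, all three groups at this position contain aromatic rings, so it remains open how the number would respond to a group without one, such as a methyl, a carboxylic acid or a longer alkyl chain. The part played by the chlorine of the 7-chloroquinolin-4-yl group is also open, since no compound shown separates its contribution from that of the rest of the group.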